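The source may hold more compounds than are shown below. What is called first, only, known or untested is meant among the compounds shown, and "the series" means these compounds.

Compound 3 has the structure `O=C(Nc1cccc(Cl)c1)c1cc(Br)cc(Br)c1`. In an assay on isolated protein for inhibition of thiosulfate sulfurtransferase (Homo sapiens), with a stated time of 60 min, in the absence of a further agent (on this read-out lower numbers stand for stronger inhibition and higher numbers for weaker inhibition), compound 3 gives > 100000 nM, which is a limit of the assay and not a number. Compound 1, with the structure `O=C(Nc1ccccc1)c1cccc(Br)c1`, gives in this assay > 100000 nM, also only a limit. Compound 2, with the structure `O=C(Nc1ccccc1)c1cc(Br)cc(Br)c1`, gives in this assay > 100000 nM, again a limit. All three values sit at the limit of > 100000 nM in this assay, at which 3 of the 3 values shown sit, so the steps a step that the two limits leave unreadable from compound 1 to compound 2 and a step that the two limits leave unreadable from compound 2 to compound 3 cannot be sized. Compound 4 has the structure `O=C(Nc1cccc(Cl)c1)c1cccc(Br)c1` and differs from compound 3 in that (hydrogen in place of bromo on an aromatic carbon). Among the measured compounds shown here, no measured step bearing on this change can be read, so no direction is expected. Compound 4 is expected to give 200000 nM, between 50000 nM and 1000000 nM, an expected step that the limit leaves unreadable from compound 3 to compound 4.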

Compound 4, half-maximal inhibitory concentration: > 100000 nM
Compound 4: a limit, no number; the forecaster's own chance of this, stated with the estimate: 85%; the middle value lies beyond the limit too.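

Compound 1, compound 3 and compound 4 all give only a limit, so the steps from compound 3 to compound 4 and from compound 1 to compound 4 cannot be read: the limit of > 100000 nM in this assay, at which 4 of the 4 values shown sit. The compounds shown leave open whether any bromo or chloro change on the shared core alters inhibition at all.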